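A methyl for a methoxy: expected Vero cell tolerance

The source may report more compounds than this note shows. Statements on the series, on what has been measured and on what is new or still open speak of the compounds shown alone.

Compound 1 `COC(=O)c1cc(-c2cccc(NC(=O)c3ccc(/C=C/C(=O)c4ccc(OC)cc4)cc3)c2)on1` gives > 10 ug/mL, a limit.
Compound 2 `COC(=O)c1cc(-c2cccc(NC(=O)c3ccc(/C=C/C(=O)c4ccc(Cl)cc4Cl)cc3)c2)on1` gives > 40 ug/mL, a limit.
Compound 3 `COC(=O)c1cc(-c2cccc(NC(=O)c3ccc(/C=C/C(=O)c4ccccc4OC)cc3)c2)on1` gives > 40 ug/mL, a limit.

In an ADME assay on Vero cells (Chlorocebus sabaeus) for cytotoxicity, read by MTT assay, with a stated time of 72 h (a higher number here means that more compound is tolerated, a lower number that less compound is tolerated), compound 3 stands only at a limit, and the two other values are limits as well. The steps that touch it, a step that the two limits leave unreadable from compound 1 to compound 3 and a step that the two limits leave unreadable from compound 2 to compound 3, are unreadable, as is a step that the two limits leave unreadable from compound 1 to compound 2; the evidence is the limit of > 10 ug/mL in this assay, at which 1 of the 3 values shown sits, and (the limit of > 40 ug/mL in this assay, at which 2 of the 3 values shown sit). Compound 4 `COC(=O)c1cc(-c2cccc(NC(=O)c3ccc(/C=C/C(=O)c4ccc(C)cc4)cc3)c2)on1` differs from compound 3 by 4-methylphenyl in place of 2-methoxyphenyl on a carbonyl carbon. With no readable step, no change beyond the scatter is expected in this assay, so the estimated step is a number no higher from compound 3 to compound 4 (the limit leaves the size open). Compound 4 is expected at 40 ug/mL, between 15 ug/mL and 80 ug/mL.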

Compound 4, half-maximal cytotoxic concentration: > 80 ug/mL
Compound 4 gave a limit, no number (the forecaster's own chance of this, stated with the estimate: 70%); middle value at least 2.0-fold (0.30 log units) away from the limit.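

In this assay compound 4 gives > 80 ug/mL, a limit, and its steps from compound 1, compound 2 and compound 3 cannot be read. The compounds shown leave open at what concentration any of them harms these cells, and whether the group on the carbonyl changes that.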